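This account rests on a few compounds, and the source may have more. Where it says the series, first, only, none or still open, it means among the compounds named here.

Compound 1 `C=C(Br)C(=O)Nc1ccc(C(=O)/C=C/c2cccc(OC)c2)cc1`: 1100 nM
Compound 2 `C=C(Br)C(=O)Nc1ccc(C(=O)/C=C/c2cc(OC)cc(OC)c2)cc1`: 2700 nM
Compound 3 `COc1cccc(/C=C/C(=O)c2ccc(N)cc2)c1`: 22000 nM

These values come from a functional assay on L1210 cells (Mus musculus) for antiproliferative activity, with a stated time of 48 h; on this read-out lower numbers stand for stronger inhibition and higher numbers for weaker inhibition. Compound 3, at 22000 nM, has the highest number of the three and is therefore the weakest inhibitor in this small set. It lacks the (1-bromoethenyl)carbonyl on the nitrogen, and removing that group gives a 20-fold higher number from compound 1 to compound 3 (1.30 log units; beyond the scatter), a large step. That step concerns a different part of the molecule, so it says little about the next comparison.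

Compound 4 `COc1cc(/C=C/C(=O)c2ccc(N)cc2)cc(OC)c1` differs from compound 3 by methoxy in place of hydrogen on an aromatic carbon. This is methoxy in place of hydrogen on an aromatic carbon, meta to a methoxy group. The same exchange has been measured once, in a 2.5-fold higher number from compound 1 to compound 2 (0.39 log units; beyond the scatter), a modest step towards weaker inhibition. That pair still carries the (1-bromoethenyl)carbonyl on the nitrogen, whereas the new pair does not, so this single precedent may transfer only loosely. A similar modest rise is expected, with the estimated change being a 2.0-fold higher number from compound 3 to compound 4 (0.31 log units; beyond the scatter). The estimate for compound 4 is 45000 nM, with an expected range of 18000 nM to 110000 nM.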

Compound 4, half-maximal inhibitory concentration: 6000 nM
The estimate for compound 4 lay 7.5-fold (0.88 log units) above the measured number; measured number outside the range, below it.
By their numbers in this assay, from the lowest: compound 1; then compound 2; then compound 4; then compound 3.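

This result shows that the added methoxy, meta to a methoxy group, has no fixed effect: with only hydrogens on the nitrogen it gives a 3.7-fold lower number from compound 3 to compound 4 (0.56 log units; beyond the scatter), the opposite direction to the rise seen when the nitrogen carries the (1-bromoethenyl)carbonyl: the same change on two cores in this assay, a 2.5-fold higher number (0.39 log units; beyond the scatter) from compound 1 to compound 2 and a 3.7-fold lower number (0.56 log units; beyond the scatter) from compound 3 to compound 4, 9.0-fold (0.95 log units) apart, beyond the scatter of two such steps

The same interplay appears from the other side, as losing the (1-bromoethenyl)carbonyl gives only a 2.2-fold higher number from compound 2 to compound 4 (0.35 log units; beyond the scatter) when both methoxy groups are present, a much smaller penalty than on the core with a single methoxy: the same change on two cores in this assay, a 20-fold higher number (1.30 log units; beyond the scatter) from compound 1 to compound 3 and a 2.2-fold higher number (0.35 log units; beyond the scatter) from compound 2 to compound 4, 9.0-fold (0.95 log units) apart, beyond the scatter of two such steps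

The two places therefore do not act independently in these four compounds, although in both pairs the compound carrying the (1-bromoethenyl)carbonyl still has the lower number.

The compounds shown leave open whether this reversal belongs to the (1-bromoethenyl)carbonyl itself or would also appear with a plain acetyl on the nitrogen. They also leave open whether a hydroxy group or a fluorine at the same ring carbon would follow the methoxy, and they offer no explanation for the reversal.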